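Same Ester Swap, Other Configuration: Forecast for Compound 4

The source may report more compounds than this note shows. Statements on the series, on what has been measured and on what is new or still open speak of the compounds shown alone.

The set comprises compound 1 `CC(C)(C)OC(=O)/C=C\NC(=O)[C@H](O)C(C)(C)CO`, compound 2 `CCOC(=O)/C=C\NC(=O)[C@H](O)C(C)(C)CO`, compound 3 `CC(C)(C)OC(=O)/C=C\NC(=O)[C@@H](O)C(C)(C)CO` and the still unmeasured compound 4 `CCOC(=O)/C=C\NC(=O)[C@@H](O)C(C)(C)CO`. All three measured members were tested in an ADME assay on HEK293 cells (Homo sapiens) for inhibition, read by CellTiter-Glo, with a stated time of 96 h, tested at 100 uM; on this read-out higher numbers stand for more inhibition at the one concentration tested (going by the name of the read-out) and lower numbers for less inhibition. There compound 1 gives -9%, compound 2 gives -6% and compound 3 gives -11%; none of the three shows appreciable inhibition at the single concentration used.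

Compound 2 differs from compound 1 by ethyl in place of tert-butyl on an oxygen next to a carbonyl group, and the step of a number 3 percentage points higher from compound 1 to compound 2 (within the scatter). Compound 3 differs from compound 1 in that (the two compounds have the same atoms and bonds and differ only in configuration as drawn: 1 of 2 stereo elements differ; a stereocentre at a saturated chain carbon is drawn R in compound 1 and S in compound 3); the step of a number 2 percentage points lower from compound 1 to compound 3 (within the scatter), and the only thing known about that pair is the fact that compounds 1 and 3 differ only in the configuration as drawn.

Compound 4 stands to compound 3 as compound 2 stands to compound 1: the difference is ethyl in place of tert-butyl on an oxygen next to a carbonyl group. This change occurs twice among the four compounds, and the place is described in identical words both times, so it is the same change, carried out on the core of compound 3 rather than that of compound 1.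

Given how little the first instance moved the read-out, the step of a number 3 percentage points higher from compound 3 to compound 4 (within the scatter) is expected for compound 4 because the same change produced a number 3 percentage points higher from compound 1 to compound 2 (within the scatter). Compound 4 is therefore estimated to give -8% in this assay, most likely between -20% and 5%.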

Compound 4, a percentage reported as inhibition, at one concentration (the size of the read-out at that concentration, not a potency): -6%
The estimate for compound 4 lay 2 percentage points below the measured number, and the stated range covers the measured number.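

Carried to the other configuration, ethyl in place of tert-butyl gave a number 5 percentage points higher from compound 3 to compound 4 (within the scatter) in this assay, while the change of configuration with the ethyl group in place gave no change at the digits printed from compound 2 to compound 4 (within the scatter). Set side by side, the two instances of the ester swap do not differ: the same change on two cores in this assay, a number 3 percentage points higher (within the scatter) from compound 1 to compound 2 and a number 5 percentage points higher (within the scatter) from compound 3 to compound 4, 2 percentage points apart, within the scatter of two such steps. This shows that the swap leaves the read-out unmoved on both cores, but with both steps within the scatter and no appreciable inhibition among the compounds, it does not show that a real effect of this change would carry from one core to another, as there is no clear effect here to carry.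

The compounds shown leave open whether a different group on an oxygen next to a carbonyl group, such as a longer chain or a benzyl group, or a carboxylic acid in place of the ester, would move the read-out in this assay. They also leave open whether the double bond drawn the other way would change the picture, and whether these four compounds would read differently at another concentration or in another cell line.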